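From Methoxy to Nitro on a Growth Inhibitor

The compounds below may be only part of what the source reports. "The series", "measured", "known", "first", "only" and "open" are said of these compounds alone.

In a functional assay on DU-145 cells (Homo sapiens) for inhibition, read by trypan blue exclusion, with a stated time of 96 h (on this read-out higher numbers stand for weaker inhibition of growth and lower numbers for stronger inhibition of growth), compound 3 (`COc1ccc(C(=O)/C(=C\c2ccc(O)c([N+](=O)[O-])c2)SCc2ccc(Br)cc2)cc1`) gives 10000 nM. Among the compounds with values here, compound 2 (`O=C(/C(=C\c1ccc(O)c([N+](=O)[O-])c1)SCc1ccc(Br)cc1)c1ccc(Cl)cc1Cl`) is level with it at 10000 nM, and these two share the highest number of the three measured so far. Compound 1 (`O=C(/C(=C\c1ccc([N+](=O)[O-])c(O)c1)SCc1ccc(Br)cc1)c1ccc([N+](=O)[O-])cc1`) gives 1000 nM, a lower number beyond the scatter.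

Compound 4 (`O=C(/C(=C\c1ccc(O)c([N+](=O)[O-])c1)SCc1ccc(Br)cc1)c1ccc([N+](=O)[O-])cc1`) departs from compound 3 in one group: nitro in place of methoxy on an aromatic carbon. This is nitro in place of methoxy on an aromatic carbon, para to a large group, so 4-methoxyphenyl becomes 4-nitrophenyl.

Within the data shown here, the one measured step at this place, 4-methoxyphenyl in place of 2,4-dichlorophenyl, shows no change at the digits printed from compound 2 to compound 3 (within the scatter), so that exchange offers no sign of movement. Compound 1, at 1000 nM, does carry the 4-nitrophenyl group, but it differs from compound 4 elsewhere on the shared core. The data do not show how much of its value goes with that group. A moderate move toward stronger inhibition of growth in this assay is therefore expected, with the expected size being a 3.3-fold lower number from compound 3 to compound 4 (0.52 log units; beyond the scatter). The estimate for compound 4 is 3000 nM, with an expected range of 700 nM to 10000 nM.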

Compound 4, concentration for 50% growth inhibition: 10000 nM
For compound 4 the middle estimate is 3.3-fold (0.52 log units) below the measured one; the range from low to high includes it.
By their numbers in this assay, from the lowest: compound 1; then compounds 2, 3 and 4 (each within the scatter of the next).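

The result shows that this position on the carbonyl side did not respond to the exchange in this assay: nitro in place of methoxy gives no change at the digits printed from compound 3 to compound 4 (within the scatter), and 4-nitrophenyl in place of 2,4-dichlorophenyl gives no change at the digits printed from compound 2 to compound 4 (within the scatter). With the 4-hydroxy-3-nitrophenyl group held fixed, the 4-methoxyphenyl, 2,4-dichlorophenyl and 4-nitrophenyl groups therefore stand level, and none of compounds 2, 3 and 4 goes against this. Within the data shown here, the 4-nitrophenyl group alone thus does not go with the lower number of compound 1, since 4-hydroxy-3-nitrophenyl in place of 3-hydroxy-4-nitrophenyl gives a 10-fold higher number from compound 1 to compound 4 (1.00 log units; beyond the scatter), the only step here beyond the scatter.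

Nothing available here accounts for the flat response at the carbonyl side or for the step at the other aromatic group. Going by these compounds, it remains open whether an amine or a carboxylic acid on this aromatic carbon would move the number, and whether methoxy and nitro would still stand level alongside the 3-hydroxy-4-nitrophenyl group of compound 1.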